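Dipropylsulfamoyl to morpholinosulfonyl on the ethyl ester series

The source may report more compounds than this note shows. Statements on the series, on what has been measured and on what is new or still open speak of the compounds shown alone.

Measured so far:
Compound 1 `CCN(CC)S(=O)(=O)c1ccc(S(=O)(=O)N2CCC[C@@H](C(=O)N[C@@H]3CCN(C(=O)OC(C)(C)C)C3)C2)cc1`: 400 nM
Compound 2 `CCCN(CCC)S(=O)(=O)c1ccc(S(=O)(=O)N2CCC[C@@H](C(=O)OCC)C2)cc1`: 2500 nM

In a functional assay on BXPC-3 cells (Homo sapiens) for inhibition, read by MTT assay, with a stated time of 7 days (on this read-out lower numbers stand for stronger inhibition and higher numbers for weaker inhibition), compound 1 gives 400 nM and compound 2 gives 2500 nM. Compound 2 stands at the higher of the two numbers; the two compounds differ in more than one place, so the pair shows only its two values and no single step can be read from it.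

Compound 3 `CCOC(=O)[C@@H]1CCCN(S(=O)(=O)c2ccc(S(=O)(=O)N3CCOCC3)cc2)C1` is the next member to be measured in this assay. It differs from compound 2 in one place: morpholin-4-yl in place of dipropylamino on a sulfonyl sulfur. For the measured compounds named here, no measured pair in this set isolates that change, so its effect has no precedent here. The ethyl ester on the shared core is kept, and the remaining piperidine-sulfonyl part is unchanged.

The step expected for compound 3 in this assay is a 1.6-fold higher number from compound 2 to compound 3 (0.20 log units; within the scatter), that is, a modest move toward a weaker or unchanged read-out, not clearly beyond the scatter. For compound 3 the estimated value in this assay is 4000 nM, with a range from 1000 nM to 15000 nM.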

Compound 3, half-maximal inhibitory concentration: 23400 nM
Compound 3: middle estimate off by 5.9-fold (0.77 log units), on the low side, and the stated range ends below it.
By their numbers in this assay, from the lowest: compound 1; then compound 2; then compound 3.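

In this assay, for the compounds shown here, morpholin-4-yl in place of dipropylamino on a sulfonyl sulfur gives a 9.4-fold higher number from compound 2 to compound 3 (0.97 log units; beyond the scatter), the first single-place step and the first sign that the read-out depends on what this position carries. With the ethyl ester and the rest of the shared core held constant, the step belongs to this change alone: dipropylamino, with no ring and no hydrogen-bond acceptor, leaves, and a six-membered non-aromatic ring with one hydrogen-bond acceptor enters. No measurement in hand accounts for the step, so it stays a bare observation on this pair.

Still open, from the compounds shown here alone, is which part of the change carries the step, the closing of the two chains into a ring or the ring oxygen; piperidin-1-yl on the same sulfonyl sulfur, with the ethyl ester kept, would separate the two, and dibutylamino would show how the read-out follows a longer chain. Also open, going by these compounds, is whether the same change has a step of similar size when the ethyl ester is replaced by the amide carried by compound 1.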